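Swapping methyl for fluoro on the aryl ketone

The source may report more compounds than this note shows. Statements on the series, on what has been measured and on what is new or still open speak of the compounds shown alone.

Three compounds share one core. Compound 1 `CCc1nnc(SCC(=O)c2ccc(C)cc2)n1N1C(=O)c2ccccc2C1=O` carries an ethyl group, compound 2 `CCCc1nnc(SCC(=O)c2ccc(C)cc2)n1N1C(=O)c2ccccc2C1=O` a propyl group, and compound 3 `COc1cc(-c2nnc(SCC(=O)c3ccc(C)cc3)n2N2C(=O)c3ccccc3C2=O)cc(OC)c1OC` a 3,4,5-trimethoxyphenyl group on the same aromatic carbon. In a functional assay on PC-3M cells (Homo sapiens) for cytotoxicity, read by MTT assay, with a stated time of 48 h (a higher number here means a weaker inhibitor, a lower number a stronger inhibitor), compound 1 gives only a limit of the assay, > 200000 nM. Compound 2 likewise reaches only the limit > 200000 nM. For the measured compounds named here, compound 3 gives 11700 nM, the only real number here, so it stands as the single measured point. The change an at least 17-fold lower number from compound 1 to compound 3 (1.23 log units; beyond the scatter) and the change an at least 17-fold lower number from compound 2 to compound 3 (1.23 log units; beyond the scatter) are both large and move toward a stronger inhibitor, while a step that the two limits leave unreadable from compound 1 to compound 2 cannot be read, since both ends sit at the limit of > 200000 nM in this assay, at which 2 of the 3 values shown sit.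

Compound 4 `COc1cc(-c2nnc(SCC(=O)c3ccc(F)cc3)n2N2C(=O)c3ccccc3C2=O)cc(OC)c1OC` differs from compound 3 only at the far end of the molecule: fluoro in place of methyl on an aromatic carbon. Going by the values given here, no measured step touches this position; the steps seen all concern the group on the other aromatic carbon. Without such a guide, the expectation is a step no larger than the scatter, a 1.0-fold higher number from compound 3 to compound 4 (0.01 log units; within the scatter). Compound 4 is therefore estimated at 12000 nM, with a likely range from 5000 nM to 30000 nM.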

Compound 4, half-maximal inhibitory concentration: > 200000 nM
Compound 4 was reported as a limit; the forecaster's own chance of this, stated with the estimate: 10%; at least 16-fold (1.22 log units) between middle value and limit.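

The far end of the molecule is not a silent position: in this assay, fluoro in place of methyl on this aromatic carbon gives an at least 17-fold higher number from compound 3 to compound 4 (1.23 log units; beyond the scatter). The earlier steps concerned only the group on the other aromatic carbon, and they linked the 3,4,5-trimethoxyphenyl group to the one real number in the set, yet compound 4 carries that same group and has no measured number, so among these compounds the group is not enough on its own; the 4-methylphenyl end is also present in the only compound with a measured value. Compound 4 now stands at a limit of the assay rather than at a number: the limit of > 200000 nM in this assay, at which 3 of the 4 values shown sit.

For the compounds shown here, with only one measured value, the true size of this loss cannot be read, and neither can any step between compounds that both sit at the limit. The compounds shown leave open whether the methyl group is special at this position or fluoro is particularly poor there, a question that a chloro, methoxy or amino group on the same aromatic carbon could help to settle.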